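A few compounds are considered here, and "the series" means these few. Any claim that something is new, unique, unknown or untested is made for them only; others in the source may bear on it.

In an ADME assay on the whole organism (plasma) for pharmacokinetics, with Rattus norvegicus as the target, at a dose of 5 mg/kg by the oral route (a lower number here means less compound in the circulation, a higher number more compound in the circulation at the dose given), compound 1 (`CCC(CC)[C@@H]1C(=O)N[C@H](C2Cc3ccccc3C2)C(=O)N1[C@@H](C(=O)N1CCOCC1)c1ccc(C)nc1`) gives 1380 ng.h/mL, and compound 2 (`Cc1ccc([C@H](C(=O)N(C)C)N2C(=O)[C@@H](C3Cc4ccccc4C3)NC(=O)[C@H]2CC(C)C)cn1`) gives 2680 ng.h/mL. Compound 3 (`CC[C@H](C)[C@@H]1C(=O)N[C@H](C2Cc3ccccc3C2)C(=O)N1[C@@H](C(=O)N(C)C)c1ccc(C)nc1C`) gives 4730 ng.h/mL, a value within the scatter of compound 2 and beyond the scatter above compound 1. Compound 4 (`CC[C@H](C)[C@@H]1C(=O)N[C@H](C2Cc3ccccc3C2)C(=O)N1[C@@H](C(=O)N(C)C)c1cc(C)cnc1C`) differs from compound 3 in one place. It carries 2,5-dimethylpyridin-3-yl in place of 2,6-dimethylpyridin-3-yl on a saturated chain carbon bound to an amide-type nitrogen in a ring and a carbonyl carbon. Within the data shown here, no measured pair of compounds differs at this place alone, so the data offer no direct guide. The step of a 1.5-fold lower number from compound 3 to compound 4 (0.17 log units; within the scatter) is expected to be a small fall, within the scatter. For compound 4 the expected value is 3200 ng.h/mL, with an estimated range of 1400 ng.h/mL to 7000 ng.h/mL.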

Compound 4, area under the concentration-time curve: 1370 ng.h/mL
Compound 4: the middle estimate sits 2.3-fold (0.37 log units) above what was measured; the measured number lies below the stated range.
By their numbers in this assay, from the lowest: compounds 4, 1, 2 and 3 (each within the scatter of the next, the first and the last beyond it).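

In this assay, 2,5-dimethylpyridin-3-yl in place of 2,6-dimethylpyridin-3-yl gives a 3.5-fold lower number from compound 3 to compound 4 (0.54 log units; beyond the scatter) on an otherwise unchanged structure. Among these compounds, the two compounds hold the same atoms, joined differently, so this position responds to where a methyl group sits on the pyridine and not only to which atoms are present, something the earlier compounds, which differ in more than one place, could not show. Nothing available explains this fall. On these data alone, whether a methoxy group or a chlorine in place of either methyl group would lower or raise the number remains open, and so does whether the same change would have the same effect with a different amide or a different side chain on the core.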